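The compounds below may be only part of what the source reports. "The series", "measured", "known", "first", "only" and "open" are said of these compounds alone.

Measured compounds: compound 2 `CCNC(=O)NCC1CCc2ccccc2N1`, compound 3 `CCNC(=S)NCC1CCc2ccccc2N1`, and compound 1 `CCC(=O)NCC1CCc2ccccc2N1CC(=O)NC`, for which the result in a functional assay on CHO cells with melatonin receptor type 1A (Homo sapiens) as the target, read by GTPgammaS binding, with a stated time of 1 h (a lower number here means that less compound is needed, a higher number that more compound is needed for the effect), is "not determined" (no result reported).

In this assay compound 2 gives 2420 nM and compound 3 gives 2660 nM. Compound 3 stands alongside compound 2 on these numbers, the step of a 1.1-fold higher number from compound 2 to compound 3 (0.04 log units; within the scatter) being within the scatter. Compound 4 `CCC(=O)NCC1CCc2ccccc2N1` differs from compound 3 by a group of 4 heavy atoms (3 carbon, 1 oxygen; no ring) in place of a group of 5 heavy atoms (3 carbon, 1 nitrogen, 1 sulfur; no ring), on an amine nitrogen. Going by the values given here, no measured step makes this same change, and the one step available, a 1.1-fold higher number from compound 2 to compound 3 (0.04 log units; within the scatter), moved little, so little movement is expected here either, in no particular direction. Compound 4 is therefore estimated at 2500 nM, with a range from 800 nM to 8000 nM, an expected step of a 1.1-fold lower number from compound 3 to compound 4 (0.03 log units; within the scatter) that should stay within the scatter.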

Compound 4, half-maximal effective concentration: 242 nM
Beside the measured number, compound 4's estimate is 10-fold (1.01 log units) above it; measured number outside the range, below it.
By their numbers in this assay, from the lowest: compound 4; then compounds 2 and 3 (each within the scatter of the next).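

In this assay, ethyl on the carbonyl carbon in place of ethylamino gives a 10-fold lower number from compound 2 to compound 4 (1.00 log units; beyond the scatter), and propanoyl in place of the sulfur-containing group gives an 11-fold lower number from compound 3 to compound 4 (1.04 log units; beyond the scatter). The group on this amine nitrogen therefore can change the number, even though the swap of oxygen for sulfur between compound 2 and compound 3 did not. Nothing available explains this drop.

Going by these compounds, whether a shorter acetyl or a longer butanoyl group would lower the number further remains open, as does the effect of a cyclopropyl group on the carbonyl carbon.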